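Anilinopyrimidine series: aryl swap at the amino nitrogen

The source may hold more compounds than are shown below. What is called first, only, known or untested is meant among the compounds shown, and "the series" means these compounds.

Measured compounds:
compound 1 `Cc1ccccc1Nc1nc(Nc2ccc(N3CCNCC3)cn2)ncc1Cl` — 5060 nM
compound 2 `COc1ccccc1CNc1nc(Nc2ccc(N3CCN(C)CC3)cn2)ncc1Cl` — 29300 nM

In a functional assay on MDA-MB-231 cells (Homo sapiens) for inhibition, read by CCK-8 assay, with a stated time of 48 h (a higher number here means a weaker inhibitor of growth, a lower number a stronger inhibitor of growth), compound 2 gives the higher of the two numbers obtained so far; compound 1 sits at a lower number, and that gap is beyond the usual scatter. Within the data shown here, no single-point step between the two measured compounds exists, so their values are read only side by side.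

Compound 3 `Cc1cc(C)c(Nc2nc(Nc3ccc(N4CCN(C)CC4)cn3)ncc2Cl)c(C)c1` is the next compound for this assay. It departs from compound 2 by 2,4,6-trimethylphenyl in place of 2-methoxybenzyl on a nitrogen on an aromatic ring.

Among the measured compounds shown here, no measured pair reports this same change, so the expected size of the step rests on the two values alone. Compound 1, the nearer analogue in carrying an aromatic ring on that nitrogen, gives 5060 nM in this assay, and compound 3 is expected to move in that direction. The step from compound 2 to compound 3 is estimated at a 3.7-fold lower number from compound 2 to compound 3 (0.56 log units; beyond the scatter). Compound 3 is accordingly estimated at 8000 nM, with a range of 2500 nM to 25000 nM.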

Compound 3, concentration for 50% growth inhibition: 21000 nM
Compound 3: middle estimate off by 2.6-fold (0.42 log units), on the low side; low and high end bracket the measured number.
By their numbers in this assay, from the lowest: compound 1; then compounds 3 and 2 (each within the scatter of the next).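

In this assay, 2,4,6-trimethylphenyl in place of 2-methoxybenzyl on this nitrogen gives a 1.4-fold lower number from compound 2 to compound 3 (0.14 log units; within the scatter), so the swap produces no readable change at this position. Attaching the aromatic ring directly to the nitrogen, with the methoxy oxygen gone as well, is therefore not enough on its own to shift the number for this pair. Compound 1 differs from compound 3 in more than one place, so the lower value of compound 1, 5060 nM, cannot be assigned to the group on this nitrogen alone.

No supporting data explain why this step is flat. Still open, from the compounds shown here alone, is whether an unsubstituted phenyl, a cyclohexyl or an alkyl chain ending in an amine on this nitrogen would move the number beyond the scatter.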